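The compounds below may be only part of what the source reports. "The series", "measured", "known", "first", "only" and "open" are said of these compounds alone.

Compound 1, `CCOC(=O)[C@H]1CCN(S(=O)(=O)c2ccc(S(=O)(=O)N(CC)CC)cc2)C1`, gives > 10000 nM in a functional assay on MIA PaCa-2 cells (Homo sapiens) for inhibition, read by MTT assay, with a stated time of 3 days; on this read-out higher numbers stand for weaker inhibition and lower numbers for stronger inhibition.
Compound 2, `CC(C)c1noc(N2CCN(C(=O)[C@@H]3CCCN(S(=O)(=O)c4ccc(S(=O)(=O)NC5CC5)cc4)C3)CC2)n1`, gives 300 nM in this assay.

The value for compound 1 is a limit of this assay and not a number, as the limit of > 10000 nM in this assay, at which 1 of the 2 values shown sits, records. Within the data shown here, compound 2 therefore stands as the only compound with a measured number in this assay, the other value shown being that limit.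

Compound 3, `CC(C)NS(=O)(=O)c1ccc(S(=O)(=O)N2CCC[C@@H](C(=O)N3CCN(c4nc(C(C)C)no4)CC3)C2)cc1`, differs from compound 2 in one place: isopropyl in place of cyclopropyl on a sulfonamide nitrogen. The groups exchanged match in their count of heavy atoms and in lacking donors and acceptors; the one departs as a three-membered ring, the other arrives as an open chain. Among the measured compounds shown here, no measured pair shows the effect of such an exchange here, so the step is expected to stay within the scatter, with no direction assumed: a 1.2-fold higher number from compound 2 to compound 3 (0.07 log units; within the scatter). Compound 3 is estimated to give 350 nM in this assay, within a range from 150 nM to 900 nM.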

Compound 3, half-maximal inhibitory concentration: 200 nM
Compound 3: the middle estimate sits 1.8-fold (0.24 log units) above what was measured; low and high end bracket the measured number.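

In this assay, among these compounds, isopropyl in place of cyclopropyl on a sulfonamide nitrogen gives a 1.5-fold lower number from compound 2 to compound 3 (0.18 log units; within the scatter), the first step in which two measured compounds differ in one place. For this pair, an open chain takes the place of a three-membered ring of carbon only, with the two values staying within the usual scatter of each other, so the ring is not needed to hold a value of this size. Nothing measured here gives a cause for this result.

The compounds shown leave open how this sulfonamide nitrogen responds to a longer chain, a phenyl ring or a hydroxyethyl group. Compound 1 differs from the other two in more than one place, so it says nothing about this position.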